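The source may hold more compounds than are shown below. What is called first, only, known or untested is meant among the compounds shown, and "the series" means these compounds.

Working notes on the series.

The shared core is seen in compound 1, `CCNCC(=O)N1N=C(c2cc3ccccc3oc2=O)CC1c1ccccc1`, where the acyl chain ends in an ethylamino group. In a functional assay on PC-3 cells (Homo sapiens) for cytotoxicity, read by MTT assay, with a stated time of 48 h (a higher number here means a weaker inhibitor, a lower number a stronger inhibitor), compound 1 gives 5580 nM. Compound 2, `O=C(CN1CCC(O)CC1)N1N=C(c2cc3ccccc3oc2=O)CC1c1ccccc1`, carries a 4-hydroxypiperidin-1-yl)methyl group on the same acyl position instead. In this assay compound 2 is reported as "not active" (no number reported), so no single number fixes where compound 2 stands; it can only be said that it falls short of compound 1, which does give a number.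

Compound 3, `NC(=O)C1CCN(CC(=O)N2N=C(c3cc4ccccc4oc3=O)CC2c2ccccc2)CC1`, differs from compound 2 in one place: carbamoyl in place of hydroxy on a saturated ring carbon. Within the data shown here, no step between measured compounds has been counted, so no step size can be read off for this change. With compound 2 giving no number, and compound 1 as the only numbered point, the expectation for compound 3 is weak inhibition at best, and a real chance that this assay again returns no number at all.

Compound 3 is expected to give about 30000 nM in this assay, within a range from 6000 nM to 100000 nM.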

Compound 3, half-maximal inhibitory concentration: 8310 nM
Beside the measured number, compound 3's estimate is 3.6-fold (0.56 log units) above it; the range from low to high includes it.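

Carbamoyl in place of hydroxy on a saturated ring carbon, three ring bonds from the ring nitrogen, separates a compound without a number from one with a number: in this assay compound 2 is reported as not active, while compound 3 gives 8310 nM. Any step to or from compound 2 cannot be read, so this change has a direction in the report but no size. On the saturated chain carbon bound to the carbonyl carbon, 4-carbamoylpiperidin-1-yl in place of ethylamino gives a 1.5-fold higher number from compound 1 to compound 3 (0.17 log units; within the scatter), which shows that this position tolerates the ethylamino group and the 4-carbamoylpiperidin-1-yl group alike in this read-out, while nothing at hand speaks to the reason for either result.

Still open, from the compounds shown here alone, is whether the carbamoyl group is specific at this ring carbon, or whether a carboxylic acid, a primary amine or a methoxy group there would also give a number in this assay. Also open, going by these compounds, is how far the acyl chain position extends this flat picture, for instance with a longer chain in place of ethylamino or with an unsubstituted piperidin-1-yl group.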